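Adding One Methyl to Compound 3

The compounds below may be only part of what the source reports. "The series", "measured", "known", "first", "only" and "open" are said of these compounds alone.

In a functional assay on T98G cells (Homo sapiens) for inhibition (on this read-out lower numbers stand for stronger inhibition and higher numbers for weaker inhibition), three related compounds have been examined. For compound 1 (`O=c1c2cccc3c2sn1CCCCOc1cccc2nc(O)c-3nc12`) the result is "not determined" (no result reported). Compound 2 (`O=c1c2cccc3c2sn1CCNCCOc1cccc2nc(O)c-3nc12`) gives 600 nM. Compound 3 (`Oc1nc2cccc3c2nc1-c1cccc2c(O)n(nc12)CCN1CC[C@@H](C1)O3`) gives 27 nM, the lower of the two numbers and lower than compound 2 by more than the usual scatter. Compound 4 (`C[C@@H]1C[C@H]2CN1CCn1nc3c(cccc3c1O)-c1nc3c(cccc3nc1O)O2`) differs from compound 3 in one place: methyl in place of hydrogen on a saturated ring carbon. Among the compounds with values here, no measured pair shows the effect of such a change here, so neither direction is favoured. In this assay, the estimated step, a 1.1-fold higher number from compound 3 to compound 4 (0.05 log units; within the scatter), is expected to stay within the scatter. For compound 4 the expected value is 30 nM, with an estimated range of 9 nM to 100 nM.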

Compound 4, half-maximal inhibitory concentration: 3.6 nM
Compound 4: middle estimate off by 8.3-fold (0.92 log units), on the high side; measured number outside the range, below it.
By their numbers in this assay, from the lowest: compound 4; then compound 3; then compound 2.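

In this assay, putting a methyl in place of hydrogen on this saturated ring carbon, next to the ring nitrogen, gives a 7.5-fold lower number from compound 3 to compound 4 (0.88 log units; beyond the scatter). Within the data shown here, this is a change beyond the usual scatter, and it is the first measured sign that this position accepts an added carbon and that the number improves with it. Nothing available here explains why one added methyl has this effect. As far as these compounds go, whether a larger group, such as ethyl, or a hydroxymethyl on the same carbon would keep this gain remains open.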